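Notes on one side-chain extension in the series

A few compounds are considered here, and "the series" means these few. Any claim that something is new, unique, unknown or untested is made for them only; others in the source may bear on it.

In a functional assay on Raji cells (Homo sapiens) for antiproliferative activity, read by CCK-8 assay, with a stated time of 48 h (a lower number here means a stronger inhibitor, a higher number a weaker inhibitor), compound 1 (`C=CC(=O)Nc1cccc(Nc2nc(Nc3ccc(OCC(=O)N(CCOC)CCOC)cc3)ncc2Cl)c1`) gives 20100 nM and compound 2 (`C=CC(=O)Nc1cccc(Nc2nc(Nc3ccc(OCC4CCCO4)cc3)ncc2Cl)c1`) gives 19100 nM. Among the compounds with values here, these are the only two numbers so far, and they lie within the scatter of each other, so compound 2 stands level with compound 1.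

Compound 3 (`C=CC(=O)Nc1cccc(Nc2nc(Nc3ccc(OCC(=O)OCC4CCCO4)cc3)ncc2Cl)c1`) is still unmeasured. It differs from compound 2 as follows: ((oxolan-2-yl)methoxy)carbonyl in place of oxolan-2-yl on a saturated chain carbon bound to an oxygen on an aromatic ring. In short, ((oxolan-2-yl)methoxy)carbonyl takes the place of oxolan-2-yl on a saturated chain carbon bound to an oxygen on an aromatic ring.

Within the data shown here, only one measured step bears on this place: a 1.1-fold lower number from compound 1 to compound 2 (0.02 log units; within the scatter). That exchange of bis(2-methoxyethyl)carbamoyl for oxolan-2-yl stays within the scatter, although the two groups differ considerably. It is a single step and involves a different entering group, so the support is thin.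

No shift beyond the scatter is expected in this assay, and no direction can be assigned. The estimated change is a 1.1-fold lower number from compound 2 to compound 3 (0.03 log units; within the scatter). For compound 3 the expected value is 18000 nM, with an estimated range of 8000 nM to 40000 nM.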

Compound 3, half-maximal inhibitory concentration: 9400 nM
For compound 3 the middle estimate is 1.9-fold (0.28 log units) above the measured one, and the stated range covers the measured number.
By their numbers in this assay, from the lowest: compound 3; then compounds 2 and 1 (each within the scatter of the next).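

In this assay, the place on a saturated chain carbon bound to an oxygen on an aromatic ring now shows a response beyond the scatter, which the pair compound 1 and compound 2 did not show: ((oxolan-2-yl)methoxy)carbonyl in place of oxolan-2-yl gives a 2.0-fold lower number from compound 2 to compound 3 (0.31 log units; beyond the scatter). Seen from the carbonyl carbon, (oxolan-2-yl)methoxy in place of bis(2-methoxyethyl)amino gives a 2.1-fold lower number from compound 1 to compound 3 (0.33 log units; beyond the scatter), so the carbonyl alone does not set the number, and compound 3 stands lowest of the three, though both steps are modest and both rest on compound 3 alone. No measurement on hand accounts for this shift.

The compounds shown leave open whether the lower number needs the oxolan-2-yl ring or only the carbonyl joined through an oxygen on that chain carbon. A carboxylic acid or a methoxycarbonyl group at the same place, read in this assay, would bear on that question, as would a longer chain between the carbonyl and the oxolan-2-yl ring.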